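The source may hold more compounds than are shown below. What is called first, only, known or untested is meant among the compounds shown, and "the series" means these compounds.

Three measured members of this series carry the same core. Compound 1 `Cc1ccc(C(=O)n2c(-c3cn(-c4ccccc4)nc3-c3ccc(C(F)(F)F)cc3)nc3ccccc32)cc1` gives 169000 nM in an ADME assay on HEK-293T cells (Homo sapiens) for cytotoxicity, read by MTT assay, with a stated time of 24 h; on this read-out lower numbers stand for higher toxicity in this test and higher numbers for lower toxicity in this test; compound 2 `Cc1ccc(C(=O)n2c(-c3cn(-c4ccccc4)nc3-c3ccc(F)cc3)nc3ccccc32)cc1` gives 178000 nM; compound 3 `Cc1ccc(-c2nn(-c3ccccc3)cc2-c2nc3ccccc3n2C(=O)c2cccc(C)c2)cc1` gives 195000 nM. All three values lie within the scatter of one another, so compound 2 sits among them without separation from compound 1 or compound 3. Among the measured compounds shown here, the only single-point step, a 1.1-fold higher number from compound 1 to compound 2 (0.02 log units; within the scatter), concerns the aryl on the pyrazole, not the acyl group. Compound 4 `O=C(c1ccccc1)n1c(-c2cn(-c3ccccc3)nc2-c2ccc(F)cc2)nc2ccccc21` differs from compound 2 by hydrogen in place of methyl on an aromatic carbon. For the measured compounds named here, no measured step touches this place, so nothing points to a shift. The expected step of a 1.0-fold higher number from compound 2 to compound 4 (0.00 log units; within the scatter) is none beyond the scatter. Compound 4 is therefore estimated at 180000 nM, with a range from 100000 nM to 320000 nM.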

Compound 4, half-maximal cytotoxic concentration: 180000 nM
Estimate against measurement, compound 4: no gap at the digits printed; the measured number falls inside the stated range.
By their numbers in this assay, from the lowest: compounds 1, 2, 4 and 3 (each within the scatter of the next).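

Replacing methyl with hydrogen on this aromatic carbon, which turns (4-methylphenyl)carbonyl into benzoyl, gives a 1.0-fold higher number from compound 2 to compound 4 (0.00 log units; within the scatter) in this assay. Among the compounds shown here, this is the first single-place reading on the acyl side, as the earlier step concerned only the other aryl, and this change shows no separation on this read-out. No evidence bearing on this result is available.

Only hydrogen and methyl are compared at this place. On these data alone, whether an amine, a carboxylic acid or a longer chain here would separate from these values remains open.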